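This account rests on a few compounds, and the source may have more. Where it says the series, first, only, none or still open, it means among the compounds named here.

Compound 1, `COc1cc(-c2nnc3n2NC(c2cccs2)C(C(=O)c2ccc(C)cc2)S3)cc(OC)c1OC`, is the reference point in this set: in a functional assay on PC-3 cells (Homo sapiens) for cytotoxicity, read by MTT assay, with a stated time of 48 h (a lower number here means a stronger inhibitor, a higher number a weaker inhibitor), compound 1 gives 5090 nM. Its partner compound 2, `COc1cc(C(=O)C2Sc3nnc(-c4cc(OC)c(OC)c(OC)c4)n3NC2c2cccs2)cc(OC)c1OC`, carries a 3,4,5-trimethoxyphenyl group on the carbonyl carbon instead of the 4-methylphenyl group of compound 1. For compound 2 the assay reports only a limit, > 100000 nM, so its true value is not pinned down. The step from compound 1 to compound 2 is accordingly an at least 19-fold higher number from compound 1 to compound 2 (1.29 log units; beyond the scatter), and compound 2 sits at the limit of > 100000 nM in this assay, at which 1 of the 2 values shown sits.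

Compound 3, `COc1ccc(C(=O)C2Sc3nnc(-c4cc(OC)c(OC)c(OC)c4)n3NC2c2cccs2)cc1`, differs from compound 2 in one place: 4-methoxyphenyl in place of 3,4,5-trimethoxyphenyl on a carbonyl carbon. For the measured compounds named here, the only measured step that bears on this change is the one from compound 1 to compound 2, where enlarging the aryl group on the carbonyl carbon to 3,4,5-trimethoxyphenyl raised the number sharply. Compound 3 reverses that enlargement toward a single-substituent phenyl, though with methoxy rather than methyl, so a lower number than for compound 2 is expected, without any evidence that the smaller group reaches the level of compound 1. The number for compound 3 is therefore estimated to lie near compound 1 rather than at the limit, namely 10000 nM, with a plausible range from 3000 nM to 40000 nM. That estimate corresponds to an expected step of an at least 10-fold lower number from compound 2 to compound 3 (1.00 log units; beyond the scatter).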

Compound 3, half-maximal inhibitory concentration: 95900 nM
For compound 3 the middle estimate is 9.6-fold (0.98 log units) below the measured one; measured number above the stated range.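

In this assay, methoxy in place of methyl on an aromatic carbon gives a 19-fold higher number from compound 1 to compound 3 (1.28 log units; beyond the scatter). The large rise seen earlier with 3,4,5-trimethoxyphenyl therefore does not need that whole group: among the compounds shown, 4-methoxyphenyl on the same carbonyl carbon is already enough to carry it. Going the other way, from the larger group to the smaller one, gives an at least 1.0-fold lower number from compound 2 to compound 3 (0.01 log units; that floor lies within the scatter), so trimming the aryl group back to 4-methoxyphenyl recovers nothing that can be read, and compound 2 is held only by a limit of the assay, not by a number: the limit of > 100000 nM in this assay, at which 1 of the 3 values shown sits.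

The compounds shown leave open whether a fluorine, a hydroxyl or an amine on that aromatic carbon, or a bare phenyl with nothing there, would sit near compound 1 or near compound 3, and so whether the rise belongs to methoxy itself or to any replacement of methyl. They also leave open how far the true number for compound 2 lies past its limit.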